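Shifting the pyridyl ether attachment in compound 3

The source may report more compounds than this note shows. Statements on the series, on what has been measured and on what is new or still open speak of the compounds shown alone.

Compound 1, `Cc1cc(Oc2ccc(-c3ccn(CCC(C)C)c(=O)c3C#N)cc2)ccn1`: 266%
Compound 2, `CCCCn1ccc(-c2ccc(Oc3ccnc(C)c3)cc2)c(C#N)c1=O`: 243%

Both were measured in a functional assay on CHO cells for positive allosteric modulation of metabotropic glutamate receptor 2 (Homo sapiens), read by scintillation counting and GTPgammaS binding, with a stated time of 30 min; on this read-out lower numbers stand for smaller maximal responses and higher numbers for larger maximal responses. Compound 2 stands lowest of the two numbers; its nearest neighbour is compound 1, and the step of a number 23 percentage points lower from compound 1 to compound 2 (beyond the scatter) concerns only the chain. Compound 3, `CCCCn1ccc(-c2ccc(Oc3cccnc3C)cc2)c(C#N)c1=O`, differs from compound 2 by 2-methylpyridin-3-yl in place of 2-methylpyridin-4-yl on an oxygen on an aromatic ring. Within the data shown here, no measured step touches this kind of change, so nothing in the data shows its direction. For compound 3 the expected step is therefore no change at the digits printed from compound 2 to compound 3 (within the scatter), none beyond the scatter. Compound 3 is estimated at 243%, between 180% and 300%.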

Compound 3, largest response reached (Emax), in percent of the reference or control that the assay uses: 228%
The estimate for compound 3 lay 15 percentage points above the measured number; the range from low to high includes it.
By their numbers in this assay, from the lowest: compound 3; then compound 2; then compound 1.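

Placing 2-methylpyridin-3-yl in place of 2-methylpyridin-4-yl on an oxygen on an aromatic ring gives in this assay a number 15 percentage points lower from compound 2 to compound 3 (beyond the scatter), so this position, and not only the chain, bears on the maximal response. The two groups have the same atoms, so this step goes with how they are joined alone. No supporting measurement accounts for it. From the compounds shown here alone, whether the step holds with the chain of compound 1 stays open. So does the outcome with an amine or a methoxy group in place of the methyl on the pyridine.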